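Swapping 3-aminophenyl for cyclopentylmethyl

The source may report more compounds than this note shows. Statements on the series, on what has been measured and on what is new or still open speak of the compounds shown alone.

- Compound 1 `CCCCCCc1ccc(C#CC#Cc2cn([C@H]3C[C@H](O)[C@@H](CO)O3)c(=O)[nH]c2=O)cc1`: 3.7
- Compound 2 `Nc1cccc(C#CC#Cc2cn([C@H]3C[C@H](O)[C@@H](CO)O3)c(=O)[nH]c2=O)c1`: 0.13
- Compound 3 `O=c1[nH]c(=O)n([C@H]2C[C@H](O)[C@@H](CO)O2)cc1C#CC#Cc1ccc([N+](=O)[O-])cc1`: 0.9

In a physicochemical assay for lipophilicity (a lower number here means a more polar compound, a higher number a more lipophilic compound), compound 2 gives 0.13, the lowest of the three numbers. Compound 4 `O=c1[nH]c(=O)n([C@H]2C[C@H](O)[C@@H](CO)O2)cc1C#CC#CCC1CCCC1` differs from it as follows: cyclopentylmethyl in place of 3-aminophenyl on a triple-bonded carbon. In words, cyclopentylmethyl stands in place of 3-aminophenyl on a triple-bonded carbon. For the measured compounds named here, two measured steps bear on this change. Placing 4-nitrophenyl at that same carbon gave a number 0.77 log units higher from compound 2 to compound 3 (beyond the scatter). Placing nitro where hexyl stood gave a number 2.80 log units lower from compound 1 to compound 3 (beyond the scatter). Neither step replaces an aromatic ring with a non-aromatic one, so the guidance is loose. An upward move is expected, larger than the first step and smaller than the second: a number 1.57 log units higher from compound 2 to compound 4 (beyond the scatter). For compound 4 the estimated value is 1.7, with an expected range of 1 to 2.4.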

Compound 4, partition coefficient: 1.43
Compound 4: middle estimate off by 0.27 log units, on the high side; the range from low to high includes it.
By their numbers in this assay, from the lowest: compound 2; then compound 3; then compound 4; then compound 1.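

For the compounds shown here, at this triple-bonded carbon, a non-aromatic ring can be compared with aromatic ones for the first time: in this assay, cyclopentylmethyl gives a number 1.30 log units higher from compound 2 to compound 4 (beyond the scatter) and a number 0.53 log units higher from compound 3 to compound 4 (beyond the scatter). The group without hydrogen-bond donors or acceptors therefore stands above both 3-aminophenyl and 4-nitrophenyl here, and both steps lie beyond the scatter. Still open, as far as these compounds go, is where an unsubstituted phenyl ring would fall at this carbon, and how far an amine or a carboxylic acid on the cyclopentyl ring would move the number. No measurement at hand explains the size of these steps.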